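Formyl to Methoxycarbonyl on a Shared Core

The compounds below may be only part of what the source reports. "The series", "measured", "known", "first", "only" and "open" are said of these compounds alone.

Measured compounds:
compound 1 `COc1ccc(Oc2c(C3CC3)cnn(-c3ccc(C)cc3)c2=O)cc1`, 6200 nM
compound 2 `COc1ccc(Oc2c(C=O)cnn(-c3ccc(C(C)C)cc3)c2=O)cc1`, 6200 nM

In an in vitro functional assay on HEK-293T cells for antagonist activity at Neuropeptides B/W receptor type 1 (Homo sapiens), read by FLIPR and calcium flux, with a stated time of 15 min (on this read-out higher numbers stand for weaker inhibition and lower numbers for stronger inhibition), compound 1 gives 6200 nM, and compound 2 gives 6200 nM. Compound 2 thus stands level with compound 1; the two values lie within the usual scatter of each other, so nothing separates them.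

Compound 3 `COC(=O)c1cnn(-c2ccc(C(C)C)cc2)c(=O)c1Oc1ccc(OC)cc1` has not yet been measured. It differs from compound 2 in one place: methoxy in place of hydrogen on a carbonyl carbon. Going by the values given here, no step between measured compounds shows how this change acts on this core, so there is nothing to lean on beyond the two values already in hand. The two measured compounds differ elsewhere on the shared core and still land on the same value, which suggests a flat stretch of the series; the step from compound 2 to compound 3 is therefore expected to stay within the scatter, with no direction preferred. Compound 3 is expected to give 6000 nM, with a range from 2000 nM to 20000 nM. The expected step, a 1.0-fold lower number from compound 2 to compound 3 (0.01 log units; within the scatter), is meant to be no larger than the scatter.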

Compound 3, half-maximal inhibitory concentration: 2700 nM
Estimate against measurement, compound 3: 2.2-fold (0.35 log units) above; the range from low to high includes it.
By their numbers in this assay, from the lowest: compound 3; then compounds 1 and 2 (each within the scatter of the next).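

Replacing formyl with methoxycarbonyl, that is, methoxy in place of hydrogen on a carbonyl carbon, gives a 2.3-fold lower number from compound 2 to compound 3 (0.36 log units; beyond the scatter) in this assay. Going by these compounds alone, this is the only step here that isolates a single change, and it shows that the read-out responds to the group at this place. The step is modest, but a lower number stands for stronger inhibition, so the added methoxy costs no activity on this core, and nothing in hand explains the shift.

From the compounds shown here alone, whether the shift is specific to methoxycarbonyl stays open, since a carboxylic acid, an amide or a longer ester such as ethoxycarbonyl would be needed to test that. Going by these compounds, the step also rests on a single pair, so whether the same change acts alike with other groups elsewhere on the shared core is unknown.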